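Swapping one methoxy group for hydrogen on compound 2

The source may hold more compounds than are shown below. What is called first, only, known or untested is meant among the compounds shown, and "the series" means these compounds.

Going by the values given here, in a functional assay on DU-145 cells (Homo sapiens) for cytotoxicity, read by MTT assay (a lower number here means a stronger inhibitor, a higher number a weaker inhibitor), compound 1 `COc1ccc2cc([C@H](C)c3nnc(SCc4c(C)cc(C)cc4C)n3-c3cccc(Cl)c3)ccc2c1` gives 93300 nM as the only exact number available here. Compound 2 `COc1cccc(CSc2nnc([C@@H](C)c3ccc4cc(OC)ccc4c3)n2-c2ccc(Cl)cc2)c1` stands at <= 400000 nM which is a limit and not a number. Compound 3 `COc1ccc2cc([C@H](C)c3n[nH]c(=S)n3-c3cccc(Cl)c3)ccc2c1` has the entry "not determined" (no result reported) and so offers no result. Compound 4 `COc1ccc2cc([C@H](C)c3nnc(SCc4ccccc4)n3-c3ccc(Cl)cc3)ccc2c1` differs from compound 2 by hydrogen in place of methoxy on an aromatic carbon in a single swap: hydrogen in place of methoxy on an aromatic carbon, turning 3-methoxybenzyl into benzyl. Among the compounds with values here, no measured pair shows this change, so in this assay only a modest gain in strength is expected, with compound 1 at 93300 nM as the sole guide. The estimate puts a step that the limit leaves unreadable from compound 2 to compound 4 as the expected step. For compound 4 the estimated value is 150000 nM with 50000 nM to 400000 nM as the expected range.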

Compound 4, half-maximal inhibitory concentration: 35800 nM
Compound 4: the middle estimate sits 4.2-fold (0.62 log units) above what was measured; the whole stated range lies above it.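

Going by these compounds alone, no step from compound 2 to compound 4 can be read, because compound 2 carries only a limit and not a number: the limit of <= 400000 nM in this assay, at which 1 of the 4 values shown sits.

Going by these compounds, how far the change from 3-methoxybenzyl to benzyl alone moves the result in this assay remains open.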